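From Chloro to Phenyl: One Change, One Expectation

A few compounds are considered here, and "the series" means these few. Any claim that something is new, unique, unknown or untested is made for them only; others in the source may bear on it.

Compound 2 `O=C(CCCc1ncc(C(F)(F)F)cc1Cl)N1CCc2c(Cl)c(O)c(O)c(Cl)c2C1` was tested in a functional assay (Homo sapiens), tested at 10 uM (on this read-out higher numbers stand for a weaker effect at the one concentration tested and lower numbers for a stronger effect), and gave 5%. Compound 1 `O=C(/C=C/c1ccccc1)N1CCc2c(Cl)c(O)c(O)c(Cl)c2C1` gave 41% in this assay, so compound 2 stands as the lower of the two numbers, with a gap beyond the usual scatter. Compound 3 `O=C(CCCc1ncc(C(F)(F)F)cc1-c1ccccc1)N1CCc2c(Cl)c(O)c(O)c(Cl)c2C1` differs from compound 2 in one place: phenyl in place of chloro on an aromatic carbon. Among the compounds with values here, no measured pair shows what a phenyl in place of chloro does here, so the expectation rests on compound 2 alone. A modest weakening is expected, a step of a number 7 percentage points higher from compound 2 to compound 3 (within the scatter) in this assay. Compound 3 is estimated at 12%, with a range from 3% to 35%.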

Compound 3, a percentage reported as activity, at one concentration (the size of the read-out at that concentration, not a potency): 38%
Compound 3: middle estimate off by 26 percentage points, on the low side; measured number outside the range, above it.
By their numbers in this assay, from the lowest: compound 2; then compounds 3 and 1 (each within the scatter of the next).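

Placing phenyl instead of chloro on this aromatic carbon, ortho to a large group, weakens the effect in this assay, giving a number 33 percentage points higher from compound 2 to compound 3 (beyond the scatter). This first measured one-place change shows that the read-out is sensitive to what sits at this position, and that this carbon does not accept every group equally. Nothing measured here explains the loss.

One pair cannot separate losing the chloro from gaining the phenyl. From the compounds shown here alone, whether a methyl group, a methoxy group or an amine on this carbon would keep the effect of compound 2 remains open.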